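A few compounds are considered here, and "the series" means these few. Any claim that something is new, unique, unknown or untested is made for them only; others in the source may bear on it.

Of the compounds shown here, two of a shared core have been tested. Compound 1 `CC1=C(C(=O)OCc2ccccc2)C(c2ccco2)NC(=O)N1` carries a benzyl ester, and in an assay on membranes from HeLa cells for displacement of a labelled ligand from adenosine receptor A3 (Homo sapiens), read by scintillation counting, with a stated time of 180 min, tested at 1 uM (a lower number here means less inhibition, a higher number more inhibition at the concentration tested (going by the name of the read-out)), compound 1 gives 3%. Compound 2 `COC(=O)C1=C(C)NC(=O)NC1c1ccoc1` carries a methyl ester and a differently attached furan, and in this assay compound 2 gives 2%. These two numbers lie within the usual scatter of each other, so compound 2 cannot be set apart from compound 1 on these data; both read as essentially no inhibition at the concentration used. Going by the values given here, compound 1 and compound 2 differ in more than one place, so no single structural step between them is drawn.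

Compound 3 `CC1=C(C(=O)OCC(C)C)C(c2ccoc2)NC(=O)N1` is obtained from compound 2 by the change (isopropyl in place of hydrogen on a saturated chain carbon bound to an oxygen next to a carbonyl group). Among the compounds with values here, no comparable step between measured compounds exists, so its size can only be guessed. Because compound 2 already gives 2% and compound 1, with a larger ester, gives 3%, the step from a number 2 percentage points higher from compound 2 to compound 3 (within the scatter) is expected to stay within the scatter, in no clear direction. Compound 3 is therefore estimated at 4%, with a range from -6% to 15%.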

Compound 3, a percentage reported as inhibition, at one concentration (the size of the read-out at that concentration, not a potency): 16%
Estimate against measurement, compound 3: 12 percentage points below; measured number outside the range, above it.
By their numbers in this assay, from the lowest: compounds 2 and 1 (each within the scatter of the next); then compound 3.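

Going by these compounds alone, the place on the saturated chain carbon bound to an oxygen next to a carbonyl group now gives the first readable step: in this assay, putting isopropyl in place of hydrogen there, which turns methoxy into isobutoxy, gives a number 14 percentage points higher from compound 2 to compound 3 (beyond the scatter) and so moves the read-out out of the scatter that had held the earlier numbers together. This shows that the read-out responds to a change at this one place, which the earlier pair could not show since those two compounds differ in more than one place, although the step is only modest and compound 3 still gives 16% at the single concentration tested. Nothing shown here explains the step, and the data give no measurement that bears on why the number rose.

The compounds shown leave open whether the number keeps climbing with a longer chain at this place, such as a straight hexyl chain, or whether it depends on the branching of the isobutyl end, and what an amine or a carboxylic acid on that chain would do. They also leave open whether the same change gives a similar step on the core with the furan attached as in compound 1, and whether any of these numbers would hold at other concentrations.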